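Hydroxy for Chloro on Two Related Cores

The compounds below may be only part of what the source reports. "The series", "measured", "known", "first", "only" and "open" are said of these compounds alone.

Compound 1 `Cc1cc(Sc2ccc(Cl)cc2)cn2c(CSCCc3ccccc3)cnc12` is tested in an ADME assay on HEL cells (Homo sapiens) for cytotoxicity, with a stated time of 3 days (a lower number here means that less compound is tolerated, a higher number that more compound is tolerated), where compound 1 gives 14 ug/mL. Compound 2 `Cc1cc(Sc2ccc(O)cc2)cn2c(CSCCc3ccccc3)cnc12` carries hydroxy in place of chloro on an aromatic carbon and gives 100 ug/mL in this assay, a step of a 7.1-fold higher number from compound 1 to compound 2 (0.85 log units; beyond the scatter). Compound 3 `Cc1cc(Sc2ccc(Cl)cc2)c2ncc(CSCCc3ccccc3)n2c1` has the same atoms as compound 1 joined differently; the difference between the two cores is not broken down here. In this assay compound 3 gives 100 ug/mL, level with compound 2 at the digits printed and, together with it, the highest of the three numbers.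

Compound 4 `Cc1cc(Sc2ccc(O)cc2)c2ncc(CSCCc3ccccc3)n2c1` is not yet measured. It differs from compound 3 by hydroxy in place of chloro on an aromatic carbon, the same change that leads from compound 1 to compound 2, made at the same kind of place on the other core. The author expects a smaller step for compound 4, a 1.5-fold higher number from compound 3 to compound 4 (0.18 log units; within the scatter), because compound 3 already stands at 100 ug/mL while the earlier step was a 7.1-fold higher number from compound 1 to compound 2 (0.85 log units; beyond the scatter) starting from a lower value. The estimate for compound 4 in this assay is 150 ug/mL, between 60 ug/mL and 350 ug/mL.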

Compound 4, half-maximal cytotoxic concentration: 79 ug/mL
For compound 4 the middle estimate is 1.9-fold (0.28 log units) above the measured one, within the range that was stated.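

In this assay, among the compounds shown here, hydroxy in place of chloro on an aromatic carbon gives a 1.3-fold lower number from compound 3 to compound 4 (0.10 log units; within the scatter), so on this core the change leaves no step that can be told from the scatter. Set beside the earlier step, the change does not carry over unchanged from one core to the other in this assay: the same change on two cores in this assay, a 7.1-fold higher number (0.85 log units; beyond the scatter) from compound 1 to compound 2 and a 1.3-fold lower number (0.10 log units; within the scatter) from compound 3 to compound 4, 9.0-fold (0.96 log units) apart, beyond the scatter of two such steps. This rests on a single pair on each core, so it shows that the size of the step differed between these two cores, but it does not show why, nor what the change would do on any further core.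

Going by these compounds, it remains open whether an amine or a methoxy group in place of chloro would follow the step seen on the core of compound 1 or the one seen on the core of compound 3. On these data alone, a carboxylic acid in that place is equally open, as is whether the gap between the cores would hold for any group other than hydroxy.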